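Removing the Hydroxy Group from the Piperidine Ring

This account rests on a few compounds, and the source may have more. Where it says the series, first, only, none or still open, it means among the compounds named here.

Measured so far:
Compound 1, `COc1cc2nc(-c3ccc(Cl)cc3)cc(OCCCN3CCCC3)c2cc1OC`: 20%
Compound 2, `COc1cc2nc(-c3ccc(Cl)cc3)cc(OCCCN3CCC(O)CC3)c2cc1OC`: 20%

In an assay on isolated protein for inhibition of DNA topoisomerase 1 (Homo sapiens), with a stated time of 30 min, tested at 1 uM (a higher number here means more inhibition at the concentration tested (going by the name of the read-out), a lower number less inhibition), compound 1 gives 20%. In this assay compound 2 gives 20%. Within the data shown here, the single measured step, no change at the digits printed from compound 1 to compound 2 (within the scatter), swapped the whole ring at the end of the chain without moving the read-out beyond the scatter, so compound 2 stands level with compound 1.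

Compound 3, `COc1cc2nc(-c3ccc(Cl)cc3)cc(OCCCN3CCCCC3)c2cc1OC`, differs from compound 2 by hydrogen in place of hydroxy on a saturated ring carbon. The step from compound 1 to compound 2 is the only one that bears on this, since it also altered the same ring, and it was flat. The change to compound 3 is smaller than that one, so no step beyond the scatter is expected: no change at the digits printed from compound 2 to compound 3 (within the scatter) is the expected step. Compound 3 is therefore estimated at 20%, with a range from 5% to 35%.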

Compound 3, a percentage reported as inhibition, at one concentration (the size of the read-out at that concentration, not a potency): 20%
For compound 3 middle estimate and measured number coincide at the digits printed; the range from low to high includes it.
By their numbers in this assay, from the lowest: compounds 1, 2 and 3 (each within the scatter of the next).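

In this assay, hydrogen in place of hydroxy on the saturated ring carbon gives no change at the digits printed from compound 2 to compound 3 (within the scatter) and so shows that the read-out at this concentration does not rest on the hydroxy, with its hydrogen-bond donor and acceptor. Piperidin-1-yl in place of pyrrolidin-1-yl gives no change at the digits printed from compound 1 to compound 3 (within the scatter) as a comparison of the two rings without the hydroxy, which the earlier pair could not offer, since compound 2 differs from compound 1 in both ring and hydroxy. Nothing available explains why these changes leave the read-out flat.

From the compounds shown here alone, with a single tested concentration and three matching values, it remains open whether any change at the end of the chain can shift the inhibition. A morpholin-4-yl ring, an open-chain dimethylamino group or a longer chain would probe this further.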